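Working notes: from compound 2 to compound 3

The compounds below may be only part of what the source reports. "The series", "measured", "known", "first", "only" and "open" are said of these compounds alone.

Of the compounds shown here, two have numbers so far in a functional assay on HeLa cells (Homo sapiens) for antiproliferative activity, with a stated time of 5 days; a lower number here means a stronger inhibitor, a higher number a weaker inhibitor. Compound 1 (`COc1ccc(-n2nc(-c3ccc4ccccc4c3)nc2N2C(=O)COC23C=CC(=O)C=C3)cc1`) gives 200 nM and compound 2 (`O=C1C=CC2(C=C1)OCC(=O)N2c1nc(-c2ccc3ncccc3c2)nn1-c1ccccc1`) gives 110 nM, and these two values lie within the scatter of each other. Compound 3 (`O=C1C=CC2(C=C1)OCC(=O)N2c1nc(-c2ccc3ccccc3c2Br)nn1-c1ccccc1`) carries 1-bromonaphthalen-2-yl in place of quinolin-6-yl on an aromatic carbon. For the measured compounds named here, no measured step isolates a change at this place, and the bromine has no precedent among the measured compounds. Compound 1, with two six-membered aromatic rings of carbon only at this place, gives 200 nM, so losing the ring nitrogen is not expected to cost much by itself. A modest move toward a higher number is expected, with the estimated step of a 2.3-fold higher number from compound 2 to compound 3 (0.36 log units; beyond the scatter). For compound 3 the estimated value is 250 nM, with an expected range of 80 nM to 800 nM.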

Compound 3, half-maximal inhibitory concentration: 290 nM
For compound 3 the middle estimate is 1.2-fold (0.06 log units) below the measured one; the range from low to high includes it.
By their numbers in this assay, from the lowest: compounds 2, 1 and 3 (each within the scatter of the next, the first and the last beyond it).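

In this assay, for the compounds shown here, 1-bromonaphthalen-2-yl in place of quinolin-6-yl gives a 2.6-fold higher number from compound 2 to compound 3 (0.42 log units; beyond the scatter), the first step that can be read at this aromatic carbon of the five-membered ring. The position therefore accepts a change that removes the ring nitrogen and adds a bromine at the same time, with a real but limited loss of activity. Nothing available on the series accounts for the size of this step.

The two changes travel together in this single step, so the shares of the bromine and of the lost ring nitrogen remain unseparated. Also open, as far as these compounds go, is how this place would respond to a chlorine on the same ring system, or to a basic amine such as a dimethylaminomethyl group.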